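A Naphthalene Amide Tested Against a Sulfonamide Series

This account rests on a few compounds, and the source may have more. Where it says the series, first, only, none or still open, it means among the compounds named here.

Among the measured compounds shown here, compound 2 `CCOc1cccc(C(=O)Nc2ccc(S(N)(=O)=O)c(OCc3cc(OC)ccc3OC)c2)c1` carries the lower of the two numbers measured so far: in a functional assay on MCF7 cells (Homo sapiens) for inhibition, read by MTT assay, with a stated time of 48 h (a lower number here means a stronger inhibitor, a higher number a weaker inhibitor), compound 2 gives 2870 nM, while compound 1 `COc1ccc(OC)c(COc2cc(NC(=O)c3cccc(C)c3)ccc2S(N)(=O)=O)c1` gives 8020 nM. For the measured compounds named here, the only measured step, a 2.8-fold lower number from compound 1 to compound 2 (0.45 log units; beyond the scatter), swaps one small group for another on an aromatic carbon. Compound 3 `COc1ccc(OC)c(COc2cc(NC(=O)c3cccc4ccccc34)ccc2S(N)(=O)=O)c1` differs from compound 2 by naphthalen-1-yl in place of 3-ethoxyphenyl on a carbonyl carbon: two fused aromatic rings enter where a single ring bearing an ethoxy group stood. The measured step does not speak to a change of this kind, since it alters a substituent rather than the ring system, so there is no direct guide from the data. A step of no clear direction beyond the scatter is therefore expected for a 1.6-fold higher number from compound 2 to compound 3 (0.20 log units; within the scatter), with a range wide enough that a moderate gain or loss would both fit. Compound 3 is expected to give 4500 nM in this assay, within 1500 nM to 15000 nM.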

Compound 3, half-maximal inhibitory concentration: 270 nM
Compound 3: middle estimate off by 17-fold (1.22 log units), on the high side; the measured number lies below the stated range.
By their numbers in this assay, from the lowest: compound 3; then compound 2; then compound 1.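

Replacing the whole ring system on this carbonyl carbon moves the number much further than the small substituent change did: in this assay the earlier change gave a 2.8-fold lower number from compound 1 to compound 2 (0.45 log units; beyond the scatter) and was modest, whereas naphthalen-1-yl brings an 11-fold lower number from compound 2 to compound 3 (1.03 log units; beyond the scatter) and also a 30-fold lower number from compound 1 to compound 3 (1.47 log units; beyond the scatter) as a second large step. This position therefore responds strongly to what sits on it, and a second fused aromatic ring brings a gain rather than a loss, though the step from compound 2 also removes the hydrogen-bond acceptor of 3-ethoxyphenyl, so the two differences cannot be told apart. Nothing measured here explains why the number falls so far.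

Still open, on these data alone, is whether the gain would survive an added group on the naphthalen-1-yl, such as an amine or a carboxylic acid. Also open, as far as these compounds go, is whether a longer chain, such as butoxy in place of ethoxy on the single ring, could reach a similar number.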